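This account rests on a few compounds, and the source may have more. Where it says the series, first, only, none or still open, it means among the compounds named here.

Measured so far:
compound 1, `COc1cc2c(Oc3ccc(NC(=O)c4nn(-c5ccccc5)cc(C)c4=O)cc3F)ccnc2cc1OCCCC(=O)NO`, 1900 nM
compound 2, `COc1cc2c(Oc3ccc(NC(=O)c4nn(-c5ccc(C)cc5)cc(C)c4=O)cc3)ccnc2cc1OCCCCCCC(=O)NO`, 2560 nM
compound 3, `COc1cc2c(Oc3ccc(NC(=O)c4nn(-c5ccc(Cl)c(C(F)(F)F)c5)cc(C)c4=O)cc3)ccnc2cc1OCC(=O)NO`, 3480 nM

All three were read in a functional assay on MCF7 cells (Homo sapiens) for inhibition, read by MTT assay, with a stated time of 72 h; on this read-out higher numbers stand for weaker inhibition and lower numbers for stronger inhibition. Compound 2 gives 2560 nM, the second highest of the three numbers. Its nearest neighbour is compound 1, which gives 1900 nM; the gap between them lies within the scatter. Compound 3 gives 3480 nM, and this gap to compound 2 also lies within the scatter. The three numbers are therefore not ordered against one another, and none of the three can be called more or less active than the others. Among the compounds with values here, no pair among them differs in one place only, so no single step has been measured.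

The next compound, compound 4, `COc1cc2c(Oc3ccc(NC(=O)c4nn(-c5ccccc5C)cc(C)c4=O)cc3)ccnc2cc1OCCCCCCC(=O)NO`, stands one change away from compound 2. The change is 2-methylphenyl in place of 4-methylphenyl on an aromatic nitrogen. The two compounds carry the same atoms, joined differently. Nothing in the measured set speaks to the effect of moving the methyl on this ring, and no shown step gives a size for it.

For this assay no step beyond the scatter is expected from compound 2 to compound 4, in either direction. The estimate for compound 4 is 2800 nM, within 1400 nM to 5600 nM, and the estimated step is a 1.1-fold higher number from compound 2 to compound 4 (0.04 log units; within the scatter).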

Compound 4, half-maximal inhibitory concentration: 1830 nM
Compound 4: the middle estimate sits 1.5-fold (0.18 log units) above what was measured; the range from low to high includes it.
By their numbers in this assay, from the lowest: compounds 4, 1, 2 and 3 (each within the scatter of the next).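

In this assay, within the data shown here, 2-methylphenyl in place of 4-methylphenyl on the aromatic nitrogen gives a 1.4-fold lower number from compound 2 to compound 4 (0.15 log units; within the scatter), the first step that changes one place only. The earlier compounds shown here differ from one another in several places at once and gave no size for any change on this ring, whereas this pair shows that the read-out does not separate these two placements of the methyl group, which carry the same atoms joined differently. Nothing shown accounts for this result, and no measurement speaks to what the methyl group does at either placement.

Still open, as far as these compounds go, is whether this position tolerates any substituent in this way, or whether a carboxylic acid or a dimethylamino group in place of the methyl group on this ring would give a step beyond the scatter. Also open, from the compounds shown here alone, is whether the same exchange of 4-methylphenyl for 2-methylphenyl reads the same way when the chain of compound 2 is replaced by the chain of compound 1 or compound 3, since only one chain has been paired here.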